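The compounds below may be only part of what the source reports. "The series", "measured", "known", "first", "only" and "open" are said of these compounds alone.

Measured so far:
compound 1, `Cc1ccc(C(=O)OC2CCN(C)CC2)cc1`: 1.17
compound 2, `CN1CCC(OC(=O)c2ccc(C(C)(C)C)cc2)CC1`: 1.13

Compound 1 stands highest of the two numbers in a functional assay on the whole organism with Mus musculus as the target (a lower number here means a less potent compound, a higher number a more potent compound, by a factor of ten per unit of this negative logarithm), and compound 2 lies nearest, the step being a number 0.04 log units lower from compound 1 to compound 2 (within the scatter); the two values are therefore indistinguishable within the scatter.

Compound 3, `Cc1ccc(C(=O)OC2CCN(C)CC2)cc1F`, is not yet measured. It differs from compound 1 as follows: fluoro in place of hydrogen on an aromatic carbon.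

Going by the values given here, no measured step involves fluoro in place of hydrogen, so no step bears directly on this change. Among the compounds with values here, the only step, a substitution on an aromatic carbon of the same ring, gave a number 0.04 log units lower from compound 1 to compound 2 (within the scatter), and the series as a whole shows no movement beyond the scatter. The expectation for compound 3 is accordingly a step of about no change at the digits printed from compound 1 to compound 3 (within the scatter), that is, none beyond the scatter. Compound 3 is expected to give 1.17, with a range from 0.7 to 1.7.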

Compound 3, logarithm of the reciprocal of the active concentration, log(1/C): 1.32
Compound 3: middle estimate off by 0.15 log units, on the low side; the range from low to high includes it.
By their numbers in this assay, from the lowest: compounds 2, 1 and 3 (each within the scatter of the next).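

In this assay, going by these compounds alone, the step of a number 0.15 log units higher from compound 1 to compound 3 (within the scatter) is the first reading at a ring hydrogen: an aromatic carbon ortho to a methyl group and meta to a large group. Fluoro at this place leaves the number within the scatter, as does the change at the methyl group itself, where the step is a number 0.04 log units lower from compound 1 to compound 2 (within the scatter). Nothing available bears on what lies behind the fluoro step.

On these data alone, it remains open whether chloro, methoxy or an amine in place of the same hydrogen would move the number beyond the scatter. The compounds shown also leave open whether a carboxylic acid or a longer chain in place of the methyl group would do so, since no change on this ring has yet produced a step beyond the scatter.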